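The source may hold more compounds than are shown below. What is called first, only, known or untested is meant among the compounds shown, and "the series" means these compounds.

Measured so far in an ADME assay on microsomes from liver (Mus musculus) for metabolic stability, read by LC-MS, with a stated time of 30 min, tested at 1 uM; a higher number here means that more of the compound is left, a lower number that less of the compound is left 
- compound 1 `O=C(NCc1ccc(S(=O)(=O)c2cccc(F)c2)cc1)c1cc2cnccc2[nH]1` at 44% 
- compound 2 `O=C(NCc1ccc(S(=O)(=O)c2ccccc2C(F)(F)F)cc1)c1cc2cnccc2[nH]1` at 41% 
- compound 3 `O=C(NCc1ccc(S(=O)(=O)N2CCCCC2)cc1)c1cc2cnccc2o1` at 4.6% 

Compound 3 is the lowest of the three, with compound 1 and compound 2 both above it beyond the scatter. The change to compound 4 `O=C(NCc1ccc(S(=O)(=O)N2CCCCC2)cc1)c1cc2cccnc2s1` is a group of 9 heavy atoms (7 carbon, 1 nitrogen, 1 sulfur; one five-membered aromatic ring with 1 hetero atom, one six-membered aromatic ring with 1 hetero atom) in place of a group of 9 heavy atoms (7 carbon, 1 nitrogen, 1 oxygen; one five-membered aromatic ring with 1 hetero atom, one six-membered aromatic ring with 1 hetero atom), on a carbonyl carbon and nothing else. For the measured compounds named here, the one measured step of a number 3 percentage points lower from compound 1 to compound 2 (within the scatter) concerns a different group and stays within the scatter, so it gives no size for this exchange. Going by the values given here, with no measured step covering it, the estimate starts from compound 3 at 4.6% and no shift beyond the scatter is expected. The estimated change is a number 3.4 percentage points higher from compound 3 to compound 4 (within the scatter) in this assay for now. For compound 4 the expected value is 8% with an estimated range of 1% to 25% at this stage.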

Compound 4, percent of the compound remaining: "below limit of detection" (no number reported)
The entry for compound 4 holds no number; no gap can be computed for the estimate.
By their numbers in this assay, from the lowest: compound 3; then compounds 2 and 1 (each within the scatter of the next).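

For the compounds shown here, compound 4 holds no number in this assay, so no step from compound 3 can be read. Nothing at hand bears on this result. Going by these compounds, how far the exchange on the carbonyl carbon shifts the percent remaining stays open.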